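Swapping a Methylphenyl for a Hydroxynaphthyl on the Hydrazone

This account rests on a few compounds, and the source may have more. Where it says the series, first, only, none or still open, it means among the compounds named here.

Three close relatives sharing one core have been tested in a functional assay on MCF7 cells (Homo sapiens) for antiproliferative activity, read by MTT assay, with a stated time of 72 h; on this read-out lower numbers stand for stronger inhibition and higher numbers for weaker inhibition. Compound 1 `CCCSc1nc(N/N=C(\C)c2ccc(OC)cc2)c2nnn(Cc3ccccc3)c2n1` reaches only the limit of > 64000 nM. Compound 3 `CCCSc1nc(N/N=C/c2cc(OC)c(OC)c(OC)c2)c2nnn(Cc3ccccc3)c2n1` likewise stops at the limit of > 64000 nM. Compound 2 `CCCSc1nc(N/N=C/c2ccc(C)cc2)c2nnn(Cc3ccccc3)c2n1` also gives only the limit, > 64000 nM. Compound 2 therefore stands exactly where every measured value sits, as the limit of > 64000 nM in this assay, at which 3 of the 3 values shown sit, shows. Compound 4 `CCCSc1nc(N/N=C/c2c(O)ccc3ccccc23)c2nnn(Cc3ccccc3)c2n1` has not yet been tested; it differs from compound 2 by 2-hydroxynaphthalen-1-yl in place of 4-methylphenyl on a carbon with a double bond to nitrogen. Among the compounds with values here, no measured step involves such a change, so the expected step of an at least 1.2-fold lower number from compound 2 to compound 4 (0.10 log units; that floor lies within the scatter) is none beyond the usual scatter, although a real number rather than a limit might be expected to appear this time. The estimate for compound 4 is 50000 nM, with a range from 15000 nM to 200000 nM.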

Compound 4, half-maximal inhibitory concentration: 6400 nM
The estimate for compound 4 lay 7.8-fold (0.89 log units) above the measured number, and the stated range ends above it.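

Placing a new group on a carbon with a double bond to nitrogen can change the outcome in this assay: 2-hydroxynaphthalen-1-yl in place of 4-methylphenyl gives an at least 10-fold lower number from compound 2 to compound 4 (1.00 log units; beyond the scatter). Compound 4 is the only one of these compounds with a real number rather than a limit. The full size of this step stays unknown because compound 2 gives only a limit: the limit of > 64000 nM in this assay, at which 3 of the 4 values shown sit.

The swap adds a second aromatic ring and a hydroxyl group together, and the compounds shown do not separate the two. From the compounds shown here alone, whether a plain naphthyl or a hydroxyphenyl group would give a similar result remains open.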